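Exchanging the Aromatic Group: An Expectation for Compound 4

The source may report more compounds than this note shows. Statements on the series, on what has been measured and on what is new or still open speak of the compounds shown alone.

Compound 1 `COC(=O)C1=C(C)N=C(C)/C(=C(\O)OC)C1c1ccccc1OC`: 57.5 nM
Compound 2 `COC(=O)C1=C(C)N=C(C)/C(=C(\O)OC)C1c1ccccc1C(F)(F)F`: 1.51 nM
Compound 3 `CCOc1ccccc1C1C(C(=O)OC)=C(C)N=C(C)/C1=C(\O)OC`: 110 nM

All three were tested in a functional assay (muscle tissue) with Cavia porcellus as the target; on this read-out higher numbers stand for an effect only at larger amounts of compound and lower numbers for an effect already at smaller amounts. Compound 1 stands second highest of the three numbers: compound 3 sits a 1.9-fold higher number from compound 1 to compound 3 (0.28 log units; within the scatter), whereas compound 2 sits a 38-fold lower number from compound 1 to compound 2 (1.58 log units; beyond the scatter). Compound 4 `COC(=O)C1=C(C)N=C(C)/C(=C(\O)OC)C1c1cccc(Cl)c1Cl` is not yet measured. It differs from compound 1 in one place: 2,3-dichlorophenyl in place of 2-methoxyphenyl on a saturated ring carbon. For the measured compounds named here, two measured steps bear on this, both replacing an oxygen-bearing group on the aromatic ring with a halogen-bearing one: the step to compound 2, and a 73-fold higher number from compound 2 to compound 3 (1.86 log units; beyond the scatter). Both were large, and halogens gave the lower numbers. A large downward step in this assay is therefore expected for compound 4, namely a 23-fold lower number from compound 1 to compound 4 (1.36 log units; beyond the scatter). Compound 4 is estimated at 2.5 nM, with a range from 0.6 nM to 12 nM.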

Compound 4, half-maximal effective concentration: 19.1 nM
Estimate against measurement, compound 4: 7.6-fold (0.88 log units) below; the measured number lies above the stated range.
By their numbers in this assay, from the lowest: compound 2; then compound 4; then compounds 1 and 3 (each within the scatter of the next).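

In this assay, 2,3-dichlorophenyl in place of 2-methoxyphenyl gives a 3.0-fold lower number from compound 1 to compound 4 (0.48 log units; beyond the scatter) and so moves the number the same way as trifluoromethyl did. That step is modest, however, against a 38-fold lower number from compound 1 to compound 2 (1.58 log units; beyond the scatter) for the trifluoromethyl exchange, so the two halogen-bearing groups at this position do not move the number equally. Nothing available offers a reason for that gap.

On these data alone, it remains open whether a single chlorine on the aromatic ring would match the two in compound 4. Where a nitro group or a nitrile there would fall is also open.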